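The source may report more compounds than this note shows. Statements on the series, on what has been measured and on what is new or still open speak of the compounds shown alone.

Measured compounds:
compound 1 `CC(C)(C)CCNC(=O)c1ccc(-c2ccccc2)cc1`: 540 nM
compound 2 `CCCCCCOc1ccc(C(=O)NCC2CCCC2(C)C)cc1`: 710 nM; 160 nM (2 entries)

In an assay for activation of potassium voltage-gated channel subfamily KQT member 1 (Cavia porcellus) (on this read-out higher numbers stand for weaker inhibition and lower numbers for stronger inhibition), compound 1 gives 540 nM, the only number shown for it; a further entry carries no single number. Compound 2 has been measured more than once, and its entries spread widely (the several entries of compound 2 in this assay, 710 nM; 160 nM (2 entries)), which shows how far repeats of this kind can lie apart. Compound 3 `CCCCCCOc1ccc(C(=O)NCCC(C)(C)C)cc1` is not yet measured. It differs from compound 1 in one place: hexyloxy in place of phenyl on an aromatic carbon. Within the data shown here, compound 2 carries the same hexyloxy group on its core with a different amide substituent, so its values give some sense of where a hexyloxy-bearing compound may fall, though no direct step is known. The expected step is a 1.5-fold lower number from compound 1 to compound 3 (0.19 log units; within the scatter), toward slightly stronger inhibition but within the scatter. Compound 3 is therefore estimated at 350 nM, with a range from 110 nM to 1100 nM.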

Compound 3, half-maximal inhibitory concentration: 250 nM
Estimate against measurement, compound 3: 1.4-fold (0.15 log units) above; low and high end bracket the measured number.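

In this assay, the position on an aromatic carbon para to a group of 9 heavy atoms accepts hexyloxy in place of phenyl with a 2.2-fold lower number from compound 1 to compound 3 (0.33 log units; beyond the scatter), the only step shown between compounds that differ in one place. The six-membered aromatic ring of carbon only is therefore not needed at this position to keep the number in this range, since an open chain with an oxygen serves there without the number rising. The step is modest, however, and repeated entries can lie further apart than this: the several entries of compound 2 in this assay, 710 nM; 160 nM (2 entries)

The compounds shown do not tell whether the oxygen or the chain accounts for the step, since hexyloxy differs from phenyl in both. A plain hexyl group, a shorter butoxy chain or a longer octyloxy chain at this position would leave that question open no longer.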